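Benzylsulfanyl variation on a low-inhibition dihydropyrimidine series

The source may report more compounds than this note shows. Statements on the series, on what has been measured and on what is new or still open speak of the compounds shown alone.

Of the compounds shown here, two have been measured. Compound 1 `CC1=C(C(=O)Nc2ccc(Br)cc2)C(c2ccc(Cl)cc2Cl)N=C(SCc2ccccc2)N1` gives 8.2% in a functional assay on the whole organism (artery, strain albino) with Rattus norvegicus as the target, with a stated time of 900 min, at a dose of 10 mg/kg by the oral route; a lower number here means less inhibition, a higher number more inhibition at the dose given (going by the name of the read-out). Going by the values given here, compound 2 `CC1=C(C(=O)Nc2ccc(Br)cc2)C(c2ccc(Cl)cc2Cl)N=C(SCc2cccc(Cl)c2)N1` gives 7.2% in this assay, and the step from chloro in place of hydrogen on an aromatic carbon is a number 1 percentage points lower from compound 1 to compound 2 (within the scatter), so compound 2 stands within the scatter of compound 1, the only other measured compound; both numbers are small.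

Compound 3 `CC1=C(C(=O)Nc2ccc(Br)cc2)C(c2ccc(Cl)cc2Cl)N=C(SCc2ccc(F)cc2)N1` is not yet measured. The change from compound 2 is 4-fluorophenyl in place of 3-chlorophenyl on a saturated chain carbon bound to a sulfur. Among the compounds with values here, the only measured step bearing on it is a number 1 percentage points lower from compound 1 to compound 2 (within the scatter), which also altered the ring on the saturated chain carbon bound to a sulfur and produced no movement beyond the scatter. No step beyond the scatter is therefore expected in this assay for compound 3, and its estimated step is a number 0.8 percentage points higher from compound 2 to compound 3 (within the scatter). Compound 3 is estimated at 8% in this assay, with an expected range from 0% to 18%.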

Compound 3, a percentage reported as inhibition, in the whole organism at one dose (the size of the read-out at that dose, not a potency): 23.1%
Compound 3: the middle estimate sits 15.1 percentage points below what was measured; measured number outside the range, above it.
By their numbers in this assay, from the lowest: compounds 2 and 1 (each within the scatter of the next); then compound 3.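

In this assay, going by these compounds alone, the ring on the saturated chain carbon bound to a sulfur is not a silent position: fluoro in place of hydrogen gives a number 14.9 percentage points higher from compound 1 to compound 3 (beyond the scatter) and is the first change here to pass beyond the scatter, as the chloro change on this ring did not. Replacing 3-chlorophenyl with 4-fluorophenyl gives a number 15.9 percentage points higher from compound 2 to compound 3 (beyond the scatter), so these two halogen-bearing rings are not interchangeable at this place, although both steps are modest. No measurement on these compounds accounts for the rise.

The names 3-chlorophenyl and 4-fluorophenyl differ in both the halogen and its ring position, and these two changes stay unseparated without 4-chlorophenyl or 3-fluorophenyl here. Also open, from the compounds shown here alone, is whether the rise carries over to 4-methoxyphenyl or to a longer chain between the sulfur and the ring.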